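The compounds below may be only part of what the source reports. "The series", "measured", "known", "first", "only" and "open" are said of these compounds alone.

Compound 1 `COc1ccc2c(OCCn3c(=O)oc4cc(C)ccc43)ccnc2c1` carries a methyl on the fused ring of its core. In a functional assay on EBC-1 cells (Homo sapiens) for inhibition, read by sulforhodamine B assay, with a stated time of 72 h (on this read-out higher numbers stand for weaker inhibition and lower numbers for stronger inhibition), compound 1 gives > 500 nM, which is a limit of the assay and not a number. Compound 2 `Cc1ccc2c(c1)oc(=O)n2CCOc1ccnc2cc(OCCCN3CCCC3)ccc12` likewise gives > 500 nM, again a limit. Compound 3 `Cc1ccc2c(c1)oc(=O)n2CCOc1ccnc2cc(OCCCN3CCN(C)CC3)ccc12` gives 170 nM. The readable steps, an at least 2.9-fold lower number from compound 1 to compound 3 (0.46 log units; beyond the scatter) and an at least 2.9-fold lower number from compound 2 to compound 3 (0.46 log units; beyond the scatter), both alter the chain on the other ring, and a step that the two limits leave unreadable from compound 1 to compound 2 stays unreadable because of the limit of > 500 nM in this assay, at which 2 of the 3 values shown sit. Compound 4 `COc1ccc2c(OCCn3c(=O)oc4cc(-c5cnn(C)c5)ccc43)ccnc2c1` differs from compound 1 in 1-methyl-1H-pyrazol-4-yl in place of methyl on an aromatic carbon. Among the measured compounds shown here, no measured step touches this position, so the size is unanchored; a modest expected improvement is set as an at least 2.0-fold lower number from compound 1 to compound 4 (0.30 log units; that floor lies within the scatter). The estimate for compound 4 is therefore 250 nM, with a range from 60 nM to 1000 nM.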

Compound 4, half-maximal inhibitory concentration: 100 nM
Estimate against measurement, compound 4: 2.5-fold (0.40 log units) above, within the range that was stated.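

Among the compounds shown here, no earlier step touched this aromatic carbon, and 1-methyl-1H-pyrazol-4-yl in place of methyl gives an at least 5.0-fold lower number from compound 1 to compound 4 (0.69 log units; beyond the scatter) in this assay with no basic chain of the kind carried by compound 3 needed for a readable value. For compound 1 the value > 500 nM is a limit of the assay and not a number. The step therefore gives only a floor on the size of this change: the limit of > 500 nM in this assay, at which 2 of the 4 values shown sit.

As far as these compounds go, whether an amine or a phenyl ring on this carbon does the same stays open. Also open, from the compounds shown here alone, is whether 1-methyl-1H-pyrazol-4-yl and the 4-methylpiperazin-1-yl chain of compound 3 add together.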